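This account rests on a few compounds, and the source may have more. Where it says the series, first, only, none or still open, it means among the compounds named here.

Measured in a functional assay on HeLa cells (Homo sapiens) for inhibition, read by MTT assay, with a stated time of 48 h; a lower number here means a stronger inhibitor of growth, a higher number a weaker inhibitor of growth:
Compound 1 `COc1ccc2c(c1)c(C1CC(c3ccc(Br)cc3)=NN1C(=O)c1ccc(OC)nc1)cn2C`: > 10000 nM
Compound 2 `COc1ccc(C2=NN(C(=O)c3ccc(OC)nc3)C(c3cn(C)c4ccc(OC)cc34)C2)cc1`: 180 nM

Among the compounds with values here, compound 2, at 180 nM, holds the only true number in this assay. Compound 1 reports only a limit, > 10000 nM. Compound 3 `COc1ccc2c(c1)c(C1CC(c3cc(OC)c(OC)c(OC)c3)=NN1C(=O)c1ccc(OC)nc1)cn2C` carries 3,4,5-trimethoxyphenyl in place of 4-methoxyphenyl on a carbon with a double bond to nitrogen. Within the data shown here, the one measured step, an at least 55-fold lower number from compound 1 to compound 2 (1.74 log units; beyond the scatter), put methoxy in place of bromo on this same ring and was large. That shows the ring can matter, but it gives no direction for this new change, so only a modest step is expected, with wide uncertainty either way. The estimated change is a 1.2-fold lower number from compound 2 to compound 3 (0.08 log units; within the scatter). Compound 3 is expected at 150 nM, with an estimated range of 25 nM to 1500 nM.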

Compound 3, concentration for 50% growth inhibition: > 10000 nM
Compound 3: no number, only a limit; the forecaster's own chance of this, stated with the estimate: 10%; at least 66-fold (1.82 log units) between middle value and limit.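

At this carbon with a double bond to nitrogen, a methoxy on the aromatic ring does not by itself secure growth inhibition in this assay: 3,4,5-trimethoxyphenyl, which still carries methoxy, gives an at least 55-fold higher number from compound 2 to compound 3 (1.74 log units; beyond the scatter). Compound 3 gives > 10000 nM, which is a limit of the assay and not a number. The step from compound 1 to compound 3 cannot be read, because both values are limits: the limit of > 10000 nM in this assay, at which 2 of the 3 values shown sit.

On these data alone, it remains open whether 3,4-dimethoxyphenyl would keep a measurable value at this place. The same is open for an amine such as 4-dimethylaminophenyl.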